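A second chloro on compound 2

The source may report more compounds than this note shows. Statements on the series, on what has been measured and on what is new or still open speak of the compounds shown alone.

Measured so far in a functional assay on NCI-H460 cells (Homo sapiens) for cytotoxicity, read by sulforhodamine B assay, with a stated time of 3 days (on this read-out higher numbers stand for weaker inhibition and lower numbers for stronger inhibition), are two compounds
Compound 1 `OCc1cn(Cc2cccc(Cl)c2)c2ccccc12` gives 19 nM
Compound 2 `OCc1cn(Cc2ccc(Cl)cc2)c2ccccc12` gives 16 nM

Compound 2 stands level with compound 1, the two values lying within the usual scatter of each other. Compound 3 `OCc1cn(Cc2ccc(Cl)c(Cl)c2)c2ccccc12` follows from compound 2 by chloro in place of hydrogen on an aromatic carbon with chloro in place of hydrogen on an aromatic carbon. Compound 1 at 19 nM and compound 2 at 16 nM show no gap beyond the scatter, so no step beyond the scatter is expected in this assay for this change. The estimated move is small: a 1.1-fold lower number from compound 2 to compound 3 (0.06 log units; within the scatter) is the step expected here. Compound 3 is expected at 14 nM with an estimated range from 5 nM to 40 nM in all.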

Compound 3, half-maximal inhibitory concentration: 31 nM
The estimate for compound 3 lay 2.2-fold (0.35 log units) below the measured number, within the range that was stated.
By their numbers in this assay, from the lowest: compounds 2, 1 and 3 (each within the scatter of the next).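

With chloro in place of hydrogen ortho to a chloro group, this assay gives a 1.9-fold higher number from compound 2 to compound 3 (0.29 log units; within the scatter). The same change read against the other single chloro compound gives a 1.6-fold higher number from compound 1 to compound 3 (0.21 log units; within the scatter), so both chloro groups can stand together on this ring with no step beyond the scatter. No measurement on hand speaks to the reason for these values.

The compounds shown leave open whether a larger step would appear with an amine, a carboxylic acid or a methoxy group at this place. They also leave open how a longer chain there would read in this assay.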